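Methylsulfonyl for Chloro on the Hydrazone Aryl Ring

This account rests on a few compounds, and the source may have more. Where it says the series, first, only, none or still open, it means among the compounds named here.

Compound 1 `Cn1c(=O)c(=O)n(C2CCCC2)c2nc(N/N=C/c3ccccc3)ncc21`: > 100000 nM
Compound 2 `Cn1c(=O)c(=O)n(C2CCCC2)c2nc(N/N=C/c3ccc(Cl)cc3)ncc21`: 9810 nM

In a functional assay on HCT-116 cells (Homo sapiens) for antiproliferative activity, read by MTT assay (on this read-out lower numbers stand for stronger inhibition and higher numbers for weaker inhibition), compound 1 reaches only a limit, > 100000 nM. For the measured compounds named here, compound 2 is the one compound of the pair with a measured number, giving 9810 nM in this assay. Going by the values given here, the step of an at least 10-fold lower number from compound 1 to compound 2 (1.00 log units; beyond the scatter) is the sole measured change; it concerns chloro in place of hydrogen on an aromatic carbon and sits on (the limit of > 100000 nM in this assay, at which 1 of the 2 values shown sits), so its true size is unknown. Compound 3 `Cn1c(=O)c(=O)n(C2CCCC2)c2nc(N/N=C/c3ccc(S(C)(=O)=O)cc3)ncc21` is not yet measured. Its change from compound 2 is methylsulfonyl in place of chloro on an aromatic carbon. Among the compounds with values here, no measured step concerns methylsulfonyl, so the earlier step gives no direction for this one. Compound 3 is therefore expected near compound 2, with a step of a 2.0-fold higher number from compound 2 to compound 3 (0.31 log units; beyond the scatter) in this assay. Compound 3 is estimated at 20000 nM, between 5000 nM and 100000 nM.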

Compound 3, half-maximal inhibitory concentration: 86600 nM
Beside the measured number, compound 3's estimate is 4.3-fold (0.64 log units) below it; measured number inside the range.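

In this assay, this position on the aromatic ring now has two substituents with measured numbers, and they do not behave alike. Replacing chloro with methylsulfonyl gives an 8.8-fold higher number from compound 2 to compound 3 (0.95 log units; beyond the scatter), a modest step towards weaker inhibition. Compound 1 stands at a limit. Replacing hydrogen with methylsulfonyl gives an at least 1.1-fold lower number from compound 1 to compound 3 (0.06 log units; that floor lies within the scatter), so this step has only a floor, and whether methylsulfonyl offers any gain over hydrogen stays unknown: the limit of > 100000 nM in this assay, at which 1 of the 3 values shown sits.

The compounds shown leave open whether the number of compound 2 is particular to chloro or would also be reached with fluoro, bromo or methyl at this place. They also leave open what an amine or a carboxylic acid would give there.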